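Fluoro to Nitro: What to Expect for Compound 4

This account rests on a few compounds, and the source may have more. Where it says the series, first, only, none or still open, it means among the compounds named here.

Of the compounds shown here, three that share a core have been tested in a functional assay on CCRF-CEM cells (Homo sapiens) for inhibition; a lower number here means a stronger inhibitor, a higher number a weaker inhibitor. Compound 1 `O=C1/C(=C/c2ccccc2Cl)Cc2ccccc21` gives 57000 nM. Compound 2 `O=C1/C(=C/c2ccccc2F)CCc2ccccc21` gives 20800 nM, the second highest of the three numbers. Compound 3 `O=C1/C(=C/c2ccc(Cl)cc2Cl)CCc2ccccc21` gives 8730 nM. Compound 2 thus sits between the other two, with compound 3 at a lower number and compound 1 at a higher one, both gaps lying beyond the usual scatter.

Compound 4 `O=C1/C(=C/c2ccccc2[N+](=O)[O-])CCc2ccccc21` is not yet measured. It differs from compound 2 by nitro in place of fluoro on an aromatic carbon, ortho to a large group. For the measured compounds named here, no measured pair shows this change, so its effect cannot be read from these data. The step from compound 2 to compound 4 is expected to be small, a 1.4-fold lower number from compound 2 to compound 4 (0.14 log units; within the scatter), toward a slightly lower number. Compound 4 is estimated at 15000 nM, within a range of 5000 nM to 50000 nM.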

Compound 4, half-maximal inhibitory concentration: 7220 nM
The estimate for compound 4 lay 2.1-fold (0.32 log units) above the measured number; measured number inside the range.
By their numbers in this assay, from the lowest: compounds 4 and 3 (each within the scatter of the next); then compound 2; then compound 1.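

In this assay, nitro in place of fluoro on an aromatic carbon, ortho to a large group, gives a 2.9-fold lower number from compound 2 to compound 4 (0.46 log units; beyond the scatter), a modest change but one beyond the scatter. For the compounds shown here, this is the only pair here that differs in one place, and it shows that this position responds to the group it carries: three heavy atoms in place of one come with stronger inhibition, not weaker. No measurement here accounts for the step.

On these data alone, whether an amine, a carboxylic acid or a methoxy group on this same carbon would lower the number further remains open. So does whether nitro would give a similar step on another carbon of this ring.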